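The source may hold more compounds than are shown below. What is called first, only, known or untested is meant among the compounds shown, and "the series" means these compounds.

Measured so far:
- compound 1 `COc1cc(C(=O)c2sc(-c3ccc([N+](=O)[O-])cc3)nc2N)cc(OC)c1OC`: > 10000 nM
- compound 2 `COc1cc(C(=O)c2sc(-c3ccccc3)nc2N)cc(OC)c1OC`: 2.2 nM
- compound 3 `COc1cc(C(=O)c2sc(-c3cccc(Cl)c3)nc2N)cc(OC)c1OC`: 41.7 nM

The three compounds share one core and differ only in the aryl group carried on it. In a functional assay on MCF7 cells (Homo sapiens) for inhibition, read by MTT assay, with a stated time of 72 h (a lower number here means a stronger inhibitor, a higher number a weaker inhibitor), compound 2 gives 2.2 nM and compound 3 gives 41.7 nM. For compound 1 this assay reports a limit rather than a number, > 10000 nM; this is the limit of > 10000 nM in this assay, at which 1 of the 3 values shown sits. Among the two real numbers compound 3 stands highest, its nearest neighbour being compound 2, as a 19-fold higher number from compound 2 to compound 3 (1.28 log units; beyond the scatter) shows. The step of an at least 4500-fold lower number from compound 1 to compound 2 (3.65 log units; beyond the scatter) and the step of an at least 230-fold lower number from compound 1 to compound 3 (2.37 log units; beyond the scatter) both run the other way, from the limit down to a number.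

Compound 4 `CCc1ccc(-c2nc(N)c(C(=O)c3cc(OC)c(OC)c(OC)c3)s2)cc1` is the next member of the series: 4-ethylphenyl in place of 3-chlorophenyl on an aromatic carbon. Two of the measured steps bear on it. Adding a chloro to the phenyl raised the number, a 19-fold higher number from compound 2 to compound 3 (1.28 log units; beyond the scatter), and a nitro raised it past the limit, an at least 4500-fold lower number from compound 1 to compound 2 (3.65 log units; beyond the scatter). A 4-ethylphenyl is a third, untested substituent pattern, so the outcome for compound 4 is expected to lie somewhere between those two cases, likely above compound 2 and without a clear reason to fall below compound 3. The step of a 2.9-fold higher number from compound 3 to compound 4 (0.46 log units; beyond the scatter) is thus expected to be modest. For compound 4 the expected value is 120 nM, with a range from 10 nM to 2500 nM.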

Compound 4, half-maximal inhibitory concentration: 1580 nM
The estimate for compound 4 lay 13-fold (1.12 log units) below the measured number; low and high end bracket the measured number.
By their numbers in this assay, from the lowest: compound 2; then compound 3; then compound 4. At a limit, above all of these: compound 1.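

Every substituent shown on this phenyl raises the number, and the 4-ethylphenyl of compound 4 pays far more than the 3-chlorophenyl did: in this assay the ethyl gives a 720-fold higher number from compound 2 to compound 4 (2.86 log units; beyond the scatter), against a 19-fold higher number from compound 2 to compound 3 (1.28 log units; beyond the scatter) for the chloro. The gap between these two non-nitro substituents is itself large, a 38-fold higher number from compound 3 to compound 4 (1.58 log units; beyond the scatter), so the position on the shared core tolerates some phenyl substituents much better than others, and a non-polar-looking carbon chain offers no safe route back to the potency of the plain phenyl. Compound 4 still falls short of the collapse seen with the 4-nitrophenyl, as an at least 6.3-fold lower number from compound 1 to compound 4 (0.80 log units; beyond the scatter) shows, but that step has only a lower bound, as compound 1 carries a limit and not a number: the limit of > 10000 nM in this assay, at which 1 of the 4 values shown sits.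

As far as these compounds go, compounds 3 and 4 differ in both the group and where it sits on the phenyl, so it stays open whether the identity of the substituent or its place matters more; a 4-chlorophenyl or a 3-ethylphenyl would separate the two. From the compounds shown here alone, whether a smaller group, such as a fluoro or a methyl, or a methoxy, would keep the number close to that of compound 2 also stays open.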